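The source may report more compounds than this note shows. Statements on the series, on what has been measured and on what is new or still open speak of the compounds shown alone.

Three analogues share one core and are compared in a functional assay on CHO cells for antagonist activity at sphingosine 1-phosphate receptor 2 (Homo sapiens), read by calcium flux; a higher number here means a weaker inhibitor, a lower number a stronger inhibitor. Compound 3 `O=C(O)Cn1nc(Cc2nc3cc(C(F)(F)F)c(OCC4CC4)cc3[nH]2)c2ccccc2c1=O` gives 6.6 nM, the lowest of the three numbers. Compound 1 `O=C(O)Cn1nc(Cc2nc3cc(Cl)c(OCC(F)F)cc3[nH]2)c2ccccc2c1=O` gives 12 nM, which sits within the scatter of compound 3, while compound 2 `O=C(O)Cn1nc(Cc2nc3cc(F)c(OCC4CC4)cc3[nH]2)c2ccccc2c1=O` gives 18 nM, beyond it. Among the measured compounds shown here, the only single-point step measured so far is a 2.7-fold lower number from compound 2 to compound 3 (0.44 log units; beyond the scatter), trifluoromethyl in place of fluoro on the aromatic carbon. Compound 4 `O=C(O)Cn1nc(Cc2nc3cc(Cl)c(OCC4CC4)cc3[nH]2)c2ccccc2c1=O` differs from compound 3 by chloro in place of trifluoromethyl on an aromatic carbon. For the measured compounds named here, no measured step covers chloro against trifluoromethyl directly; compound 1 also carries chloro, with a different alkoxy group, and its value lies within the scatter of compound 3. Compound 4 is therefore expected near 10 nM (range 4 nM to 25 nM). The implied step a 1.5-fold higher number from compound 3 to compound 4 (0.18 log units; within the scatter) is expected to remain within the scatter.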

Compound 4, half-maximal inhibitory concentration in the sphingosine 1-phosphate receptor 2 assay: 8.8 nM
Beside the measured number, compound 4's estimate is 1.1-fold (0.06 log units) above it; low and high end bracket the measured number.
By their numbers in the sphingosine 1-phosphate receptor 2 assay, from the lowest: compounds 3, 4, 1 and 2 (each within the scatter of the next, the first and the last beyond it).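

In the sphingosine 1-phosphate receptor 2 assay, chloro on this aromatic carbon stays level with trifluoromethyl, a 1.3-fold higher number from compound 3 to compound 4 (0.12 log units; within the scatter), while it improves on fluoro, a 2.0-fold lower number from compound 2 to compound 4 (0.31 log units; beyond the scatter). In the sphingosine 1-phosphate receptor 2 assay, with chloro held constant, the alkoxy change of cyclopropyl in place of difluoromethyl gives a 1.4-fold lower number from compound 1 to compound 4 (0.13 log units; within the scatter), so no difference is resolved. In a physicochemical assay for lipophilicity, at pH 7.4 (a higher number here means a more lipophilic compound, a lower number a more polar compound), compound 3 gives 2.79 and compound 4 gives 2.21 as measured. Chloro therefore keeps the receptor number of trifluoromethyl while lowering lipophilicity in the physicochemical assay: the measured distribution coefficient of compound 3, 2.79, and of compound 4, 2.21, a number 0.58 log units lower (beyond the scatter)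

Open, going by these compounds, is how a nitrile or a methyl group on this aromatic carbon would stand in the sphingosine 1-phosphate receptor 2 assay and in the physicochemical assay.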